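A few compounds are considered here, and "the series" means these few. Any claim that something is new, unique, unknown or untested is made for them only; others in the source may bear on it.

In a functional assay on MCF7 cells (Homo sapiens) for inhibition, read by sulforhodamine B assay, with a stated time of 48 h, tested at 50 uM (on this read-out lower numbers stand for less inhibition of growth and higher numbers for more inhibition of growth at the one concentration tested), three compounds have been measured. Their values fall as the groups attached to the shared core grow, from compound 1 (`COc1cc2c(cc1CCC(C)C)C(=O)C[C@@H](c1ccc(O)cc1)O2`) at 81%, through compound 2 (`CCCCOc1ccc([C@@H]2CC(=O)c3cc(CC=C(C)C)c(OC)cc3O2)cc1`) at 57%, to compound 3 (`COc1ccc([C@@H]2C/C(=N/OCc3cn(-c4ccc(NC(=O)c5ccccc5)cc4)nn3)c3cc(CC=C(C)C)c(OC)cc3O2)cc1`) at 4%. Compound 2 is therefore second highest of the three, and its gaps to both others lie beyond the usual scatter. Compound 4 (`COc1cc2c(cc1CC=C(C)C)C(=O)C[C@@H](c1ccc(Oc3ccc(Br)cc3)cc1)O2`) has 4-bromophenyl in place of butyl on an oxygen on an aromatic ring. Within the data shown here, no measured pair isolates this change, so the trend across these three compounds is the only guide. A moderate drop, slightly beyond the scatter, is expected, an estimated a number 15 percentage points lower from compound 2 to compound 4 (beyond the scatter). For compound 4 the estimated value is 42%, with an expected range of 18% to 68%.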

Compound 4, percent growth inhibition at one concentration: 68%
Estimate against measurement, compound 4: 26 percentage points below; measured number inside the range.
By their numbers in this assay, from the lowest: compound 3; then compound 2; then compound 4; then compound 1.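

In this assay, placing 4-bromophenyl instead of butyl on this oxygen moves the value a number 11 percentage points higher from compound 2 to compound 4 (beyond the scatter) and the step is modest. This position therefore carries a larger group with a ring of its own and the growth inhibition does not fall, so a bigger group here does not by itself lower the number. Nothing available explains the rise. Whether the bromine or the phenyl ring accounts for the step stays open, and so does the outcome with plain phenyl, a longer chain such as hexyl, or a chain ending in an amine on this oxygen.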